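Swapping methoxy for tert-butyl on compound 3

The source may report more compounds than this note shows. Statements on the series, on what has been measured and on what is new or still open speak of the compounds shown alone.

Measured so far in a functional assay on B16-F0 cells (Mus musculus) for inhibition, read by CCK-8 assay, with a stated time of 48 h; on this read-out lower numbers stand for stronger inhibition and higher numbers for weaker inhibition
- compound 1 `COc1cc(-c2ccnc3cc(-c4ccccc4)nn23)cc(OC)c1OC` gives 4730 nM
- compound 2 `COc1cc(-c2ccnc3cc(-c4ccc5c(ccn5C)c4)nn23)cc(OC)c1OC` gives 48 nM
- compound 3 `COc1ccc(-c2cc3nccc(-c4cc(OC)c(OC)c(OC)c4)n3n2)cc1` gives 1410 nM

Compound 3, at 1410 nM, stands in the middle of these three numbers. It lies below compound 1, as the step shows (a 3.4-fold lower number from compound 1 to compound 3 (0.53 log units; beyond the scatter)), and well above compound 2 (a 29-fold higher number from compound 2 to compound 3 (1.47 log units; beyond the scatter)).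

The next compound is compound 4 `COc1cc(-c2ccnc3cc(-c4ccc(C(C)(C)C)cc4)nn23)cc(OC)c1OC`. It keeps the shared core and has tert-butyl in place of methoxy on an aromatic carbon, para to a large group (tert-butyl in place of methoxy on an aromatic carbon).

Among the measured compounds shown here, no measured step makes this exact swap, so the evidence is indirect. The nearest guide is the step that added the methoxy (a 3.4-fold lower number from compound 1 to compound 3 (0.53 log units; beyond the scatter)), which was modest. The step to the 1-methyl-1H-indol-5-yl group (a 99-fold lower number from compound 1 to compound 2 (1.99 log units; beyond the scatter)) was large, so a change at this place can matter a great deal, but it says little about tert-butyl. With so few compounds, the direction is only a tentative guess: losing the methoxy may give back part of its modest gain. The expected change is small (a 2.1-fold higher number from compound 3 to compound 4 (0.33 log units; beyond the scatter)). Compound 4 is estimated at 3000 nM (expected range 800 nM to 10000 nM).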

Compound 4, half-maximal inhibitory concentration: > 10000 nM
Compound 4: a limit, no number; the forecaster's own chance of this, stated with the estimate: 5%; middle value at least 3.3-fold (0.52 log units) from the limit.
By their numbers in this assay, from the lowest: compound 2; then compound 3; then compound 1. At a limit, above all of these: compound 4.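

For compound 4 the reading of > 10000 nM in this assay is a limit of the assay and not a number. Among the compounds shown here, until now, both groups placed on this aromatic ring had lowered the number compared with the plain phenyl of compound 1, but tert-butyl in place of hydrogen is the first change to raise it (an at least 2.1-fold higher number from compound 1 to compound 4 (0.32 log units; beyond the scatter)), and tert-butyl in place of methoxy does more than give back the modest gain from methoxy (an at least 7.0-fold higher number from compound 3 to compound 4 (0.85 log units; beyond the scatter)). The gap to the compound carrying 1-methyl-1H-indol-5-yl is the widest shown so far (an at least 200-fold higher number from compound 2 to compound 4 (2.31 log units; beyond the scatter)), so the group at this place can take the series from the lowest number shown all the way to the limit: the limit of > 10000 nM in this assay, at which 1 of the 4 values shown sits.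

As far as these compounds go, whether an ethyl or isopropyl group at this place would read more like methoxy or more like tert-butyl stays open, as does how a hydroxyl, an amine or a carboxylic acid would read there. From the compounds shown here alone, it is also open whether the strong result with 1-methyl-1H-indol-5-yl would hold if the shared core were changed elsewhere.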